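Removing the ring double bond on the shared core

This account rests on a few compounds, and the source may have more. Where it says the series, first, only, none or still open, it means among the compounds named here.

Of the compounds shown here, three on the shared core have been measured in an assay on CHO cells for displacement of a labelled ligand from Substance-P receptor (Homo sapiens), in the presence of a further agent that is not named here; on this read-out higher numbers stand for weaker inhibition and lower numbers for stronger inhibition. Compound 1 `C[C@@H](O[C@H]1CN2C(=O)C=C(c3ccc(F)cc3)CC2[C@@H]1c1ccc(F)cc1)c1cc(C(F)(F)F)cc(C(F)(F)F)c1` gives 100 nM. Compound 2 `C[C@@H](O[C@H]1CN2C(=O)C=C(c3cnn(Cc4ccccc4)c3)CC2[C@@H]1c1ccc(F)cc1)c1cc(C(F)(F)F)cc(C(F)(F)F)c1` gives 66 nM, and the step of a 1.5-fold lower number from compound 1 to compound 2 (0.18 log units; within the scatter) lies within the scatter. Compound 3 `C[C@@H](O[C@H]1CN2C(=O)C=C(C3=CCOCC3)CC2[C@@H]1c1ccc(F)cc1)c1cc(C(F)(F)F)cc(C(F)(F)F)c1` gives 9.6 nM, the lowest of the three numbers and beyond the scatter from both others, with a 10-fold lower number from compound 1 to compound 3 (1.02 log units; beyond the scatter) and a 6.9-fold lower number from compound 2 to compound 3 (0.84 log units; beyond the scatter). Compound 3 is therefore the strongest inhibitor measured so far.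

Compound 4 `C[C@@H](O[C@H]1CN2C(=O)C=C(C3CCOCC3)CC2[C@@H]1c1ccc(F)cc1)c1cc(C(F)(F)F)cc(C(F)(F)F)c1` has not yet been measured. It differs from compound 3 by a group of 6 heavy atoms (5 carbon, 1 oxygen; one six-membered non-aromatic ring with 1 hetero atom) in place of a group of 6 heavy atoms (5 carbon, 1 oxygen; one six-membered non-aromatic ring with 1 hetero atom), on a double-bonded ring carbon: the ring keeps its size and its single oxygen, and only the double bond outside aromatic rings is removed. Within the data shown here, none of the measured steps bears directly on this change; each of them exchanges one group for a quite different one on the same double-bonded ring carbon, whereas here the same ring is kept with one double bond fewer. The measured steps show that this carbon tolerates wide variation, the non-aromatic ring of compound 3 giving the lowest number. Among the measured compounds shown here, with no measured step separating a ring with this double bond from one without it, no change beyond the scatter is expected, so the estimated step of a 1.3-fold higher number from compound 3 to compound 4 (0.10 log units; within the scatter) is small. Compound 4 is expected to give about 12 nM in this assay, with a range from 4 nM to 40 nM.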

Compound 4, half-maximal inhibitory concentration: 3.2 nM
Beside the measured number, compound 4's estimate is 3.8-fold (0.57 log units) above it, and the stated range ends above it.
By their numbers in this assay, from the lowest: compound 4; then compound 3; then compounds 2 and 1 (each within the scatter of the next).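

In this assay removing the double bond outside aromatic rings from the group on this double-bonded ring carbon gives a 3.0-fold lower number from compound 3 to compound 4 (0.48 log units; beyond the scatter) and so counts as a change in its own right, even though ring size and the single oxygen stay the same. For this one pair, that double bond is not required for the low numbers, and the saturated oxan-4-yl ring stands further from the aromatic groups, with a 21-fold lower number from compound 2 to compound 4 (1.31 log units; beyond the scatter) and a 31-fold lower number from compound 1 to compound 4 (1.49 log units; beyond the scatter) on the same carbon, which makes compound 4 the strongest inhibitor of the four. No supporting data bear on this result, so the gain from losing the double bond stays unexplained.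

Open is whether the oxygen of oxan-4-yl matters at all, since the compounds shown hold neither a cyclohexyl ring nor an amine such as a piperidine ring on this carbon. Also open, from the compounds shown here alone, is how a longer open chain or a carboxylic acid here would compare with compound 4, and whether removing a double bond gives a similar step on any other ring.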